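Sulfone for nitro on the ether side chain

The compounds below may be only part of what the source reports. "The series", "measured", "known", "first", "only" and "open" are said of these compounds alone.

Measured so far:
compound 1 `COC(C)CCOCn1cc[n+](C)c1/C=N/O` — -2.22
compound 2 `C[n+]1ccn(COCC(C)(C)CBr)c1/C=N/O` — -0.81
compound 3 `C[n+]1ccn(COCC[N+](=O)[O-])c1/C=N/O` — no number reported

For the measured compounds named here, in a physicochemical assay for lipophilicity (on this read-out lower numbers stand for lower lipophilicity and higher numbers for higher lipophilicity), compound 1 gives -2.22 and compound 2 gives -0.81; the single measured step, a number 1.41 log units higher from compound 1 to compound 2 (beyond the scatter), belongs to a different exchange. Compound 3 stands nowhere on these numbers: in this assay compound 3 gives no result reported. The change under study is methylsulfonyl in place of nitro on a saturated chain carbon, two bonds along the chain from an oxygen on a saturated carbon, which gives compound 4 `C[n+]1ccn(COCCS(C)(=O)=O)c1/C=N/O`. Going by the values given here, no measured step bears on this exchange, and the one step that exists does not share either group, so no step size in this assay can be read off from the series; nothing beyond the scatter is assumed. Compound 4 is expected at -2.4, with a range from -3.2 to -1.6.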

Compound 4, distribution coefficient: < -3.3
Compound 4 was reported as a limit (the forecaster's own chance of this, stated with the estimate: 10%); middle value at least 0.90 log units away from the limit.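

In this assay the value of compound 4 is a limit and not a number: the limit of < -3.3 in this assay, at which 1 of the 4 values shown sits. With the core unchanged, the ether side chain carries a number at least 2.49 log units lower from compound 2 to compound 4 (beyond the scatter) and a number at least 1.08 log units lower from compound 1 to compound 4 (beyond the scatter) as steps, both beyond the scatter and both bounded by that limit. This position therefore reaches further down the read-out than compounds 1 and 2 showed. Compound 3 has no number, so the exchange of nitro for methylsulfonyl cannot be read as a step. Open, going by these compounds, are how far compound 4 lies from its limit and where a side chain ending in a carboxylic acid or an amine, or a longer chain bearing methylsulfonyl, would stand in this assay.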